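The source may hold more compounds than are shown below. What is called first, only, known or untested is meant among the compounds shown, and "the series" means these compounds.

Compound 1, `Cc1cccc(NC(=O)Nc2cccc(CNc3ncnc4ccccc34)c2)c1`, gives 30200 nM in a functional assay on A549 cells (Homo sapiens) for antiproliferative activity, read by MTT assay; a lower number here means a stronger inhibitor, a higher number a weaker inhibitor.
Compound 2, `Cc1ccc(NC(=O)Nc2cccc(CNc3ncnc4ccccc34)c2)cc1`, gives 24900 nM in this assay.
Compound 3, `COc1cc2ncnc(NCc3cccc(NC(=O)Nc4cccc(C)c4)c3)c2cc1OC`, gives 27100 nM in this assay.

These three compounds lie close to one another: the step of a 1.2-fold lower number from compound 1 to compound 2 (0.08 log units; within the scatter) is within the scatter, and compound 3 sits between the other two with gaps that are also within the scatter. Compound 3 carries a different core from compound 1; the difference between the two cores is not broken down here.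

Compound 4, `COc1cc2ncnc(NCc3cccc(NC(=O)Nc4ccc(C)cc4)c3)c2cc1OC`, has not yet been measured in this assay. It differs from compound 3 by 4-methylphenyl in place of 3-methylphenyl on an amide-type nitrogen. This is the same change as 4-methylphenyl in place of 3-methylphenyl on an amide-type nitrogen, made on the same kind of amide-type nitrogen whose other neighbour is a carbonyl carbon, and it occurs twice among the compounds shown.

Because the earlier instance of this change gave a 1.2-fold lower number from compound 1 to compound 2 (0.08 log units; within the scatter), a step of similar size is expected from compound 3 to compound 4, namely a 1.2-fold lower number from compound 3 to compound 4 (0.08 log units; within the scatter). Compound 4 is therefore estimated at 22500 nM in this assay, with an expected range from 11000 nM to 45000 nM.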

Compound 4, half-maximal inhibitory concentration: 12900 nM
Compound 4: the middle estimate sits 1.7-fold (0.24 log units) above what was measured, within the range that was stated.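

In this assay, putting 4-methylphenyl in place of 3-methylphenyl on the amide-type nitrogen gave a 2.1-fold lower number from compound 3 to compound 4 (0.32 log units; beyond the scatter), a modest step on the core of compound 3. Set beside the earlier instance of the change on the core of compound 1, this step does not differ from it by more than the scatter: the same change on two cores in this assay, a 1.2-fold lower number (0.08 log units; within the scatter) from compound 1 to compound 2 and a 2.1-fold lower number (0.32 log units; beyond the scatter) from compound 3 to compound 4, 1.7-fold (0.24 log units) apart, within the scatter of two such steps. The two cores therefore give no evidence that the change behaves differently from one to the other, but with a single pair on each core this does not show that the two steps are equal, nor does it predict the step on any further core.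

The compounds shown leave open whether a chloro or a trifluoromethyl group in place of the methyl on the phenyl ring would give a step of similar size on these two cores. They also leave open whether ethoxy groups in place of the methoxy groups of compound 3 and compound 4 would alter the numbers in this assay.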